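This account rests on a few compounds, and the source may have more. Where it says the series, first, only, none or still open, it means among the compounds named here.

Measured in a functional assay on MIA PaCa-2 cells (Homo sapiens) for inhibition, read by MTT assay, with a stated time of 3 days; on this read-out lower numbers stand for stronger inhibition and higher numbers for weaker inhibition:

- compound 1, `CCN(CC)S(=O)(=O)c1ccc(S(=O)(=O)N2CCC[C@@H](C(=O)N[C@@H]3CCN(C(=O)OC(C)(C)C)C3)C2)cc1`: 500 nM
- compound 2, `CCOC(=O)[C@@H]1CCC[C@@H](S(=O)(=O)c2ccc(S(=O)(=O)N(CC)CC)cc2)C1`: 5000 nM
- compound 3, `CCN(CC)C(=O)[C@@H]1CCCN(S(=O)(=O)c2ccc(S(=O)(=O)N(CC)CC)cc2)C1`: 700 nM

Compound 3 stands second highest of the three numbers. Its nearest neighbour is compound 1, which lies within the scatter of it; its furthest is compound 2, which lies beyond the scatter, on the weaker side. Compound 4, `CCN(CC)S(=O)(=O)c1ccc(S(=O)(=O)N2CCC[C@@H](C(=O)NC)C2)cc1`, is compound 3 with methylamino in place of diethylamino on a carbonyl carbon. Within the data shown here, no measured pair in this set isolates that change, so nothing here fixes its size. The expectation is no step beyond the scatter, with a lean toward a slightly higher number, since the bulkier amides of compound 1 and compound 3 both sit in the same band. Compound 4 is therefore estimated at 1200 nM in this assay, range 400 nM to 3500 nM, a step of a 1.7-fold higher number from compound 3 to compound 4 (0.23 log units; within the scatter) expected.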

Compound 4, half-maximal inhibitory concentration: 2000 nM
Beside the measured number, compound 4's estimate is 1.7-fold (0.22 log units) below it; measured number inside the range.
By their numbers in this assay, from the lowest: compounds 1 and 3 (each within the scatter of the next); then compound 4; then compound 2.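

In this assay, among these compounds, this position proves responsive for the first time: methylamino in place of diethylamino on a carbonyl carbon gives a 2.9-fold higher number from compound 3 to compound 4 (0.46 log units; beyond the scatter) and is a real loss. Methyl in place of 1-(tert-butoxycarbonyl)pyrrolidin-3-yl on an amide-type nitrogen gives a 4.0-fold higher number from compound 1 to compound 4 (0.60 log units; beyond the scatter) on the same weaker side, so both larger amides hold an edge over the methyl amide. No measured evidence bears on the origin of these steps. Still open, on these data alone, is whether ethylamino or dimethylamino on the carbonyl carbon tracks with compound 3 or compound 4, and how hydroxy there, as the carboxylic acid, would read.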